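Dropping the aromatic substituent from the shared core

A few compounds are considered here, and "the series" means these few. Any claim that something is new, unique, unknown or untested is made for them only; others in the source may bear on it.

Compound 3 `c1ccc(-c2cccc3c2CCC3c2ncc[nH]2)nc1` has been measured in a functional assay on CHO cells for agonist activity at Alpha-1A adrenergic receptor (Homo sapiens), read by FLIPR and calcium flux (on this read-out lower numbers stand for an effect already at smaller amounts and higher numbers for an effect only at larger amounts of compound), where compound 3 gives 1150 nM. Of the two numbers shown it stands highest; its nearest neighbour, compound 2 `Cc1oncc1-c1cccc2c1CCC2c1ncc[nH]1`, gives 111 nM in this assay, and the step of a 10-fold higher number from compound 2 to compound 3 (1.02 log units; beyond the scatter) is large. Compound 1 `Cn1cc(-c2cccc3c2CCC3c2ncc[nH]2)cn1` gives > 2900 nM in this assay, which is a limit of the assay and not a number, as recorded in the limit of > 2900 nM in this assay, at which 1 of the 3 values shown sits.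

Compound 4 `c1ccc2c(c1)CCC2c1ncc[nH]1` differs from compound 3 in one place: hydrogen in place of pyridin-2-yl on an aromatic carbon. For the measured compounds named here, none of the measured steps matches this change. Each of them exchanges one aromatic group for another on the same carbon: an at least 26-fold lower number from compound 1 to compound 2 (1.41 log units; beyond the scatter), an at least 2.5-fold lower number from compound 1 to compound 3 (0.40 log units; beyond the scatter), and the step from compound 2 to compound 3 already named. They show that the group in this place moves the number by a large amount, but they do not show what happens when it is removed altogether, so the direction of the step to compound 4 rests on a guess. With the substituent gone, a higher number is expected for compound 4, with the step of a 3.0-fold higher number from compound 3 to compound 4 (0.48 log units; beyond the scatter) estimated as likely but uncertain in size. The estimate for compound 4 in this assay is 3500 nM, expected to lie between 600 nM and 20000 nM.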

Compound 4, half-maximal effective concentration: 473 nM
Estimate against measurement, compound 4: 7.4-fold (0.87 log units) above; measured number outside the range, below it.
By their numbers in this assay, from the lowest: compound 2; then compound 4; then compound 3. At a limit, above all of these: compound 1.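

Hydrogen on this aromatic carbon turns out to be a reference point that the earlier exchanges of one aromatic group for another could not supply: in this assay the shared core needs no aromatic group here to give a number in the same range as the substituted compounds. Against that reference, the groups part ways, since removing pyridin-2-yl gives a lower number (a 2.4-fold lower number from compound 3 to compound 4 (0.39 log units; beyond the scatter)), whereas removing 5-methyl-1,2-oxazol-4-yl gives a higher one (a 4.3-fold higher number from compound 2 to compound 4 (0.63 log units; beyond the scatter)), so of the three groups only 5-methyl-1,2-oxazol-4-yl improves on hydrogen, and compound 3 and compound 1 go against any rule that an aromatic group here lowers the number. The step for 1-methyl-1H-pyrazol-4-yl (an at least 6.1-fold lower number from compound 1 to compound 4 (0.78 log units; beyond the scatter)) points the same way as that for pyridin-2-yl, but its size is only a bound, as compound 1 stands at a limit of the assay and not at a number: the limit of > 2900 nM in this assay, at which 1 of the 4 values shown sits.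

From the compounds shown here alone, what remains open is how small non-aromatic groups, such as a methyl, a methoxy or an amine, would compare with hydrogen on this carbon. Also open, going by these compounds, is whether the methyl of 5-methyl-1,2-oxazol-4-yl contributes to its lower number, which the parent 1,2-oxazol-4-yl would test.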